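The source may hold more compounds than are shown below. What is called first, only, known or untested is meant among the compounds shown, and "the series" means these compounds.

Measured compounds:
compound 1 `O=S(=O)(NCCNC(=S)Nc1cc(C(F)(F)F)cc(C(F)(F)F)c1)c1cc(-c2ccccc2Oc2ccc(O)c(O)c2)cs1` — 4600 nM
compound 2 `Cc1ccc(-c2ccsc2S(=O)(=O)NCCNC(=O)Nc2ccc([N+](=O)[O-])cc2)c(Oc2ccc(O)c(O)c2)c1` — 13000 nM
compound 3 `O=C(NCCNS(=O)(=O)c1cc(-c2ccccc2Oc2ccc(O)c(O)c2)cs1)Nc1cc(Cl)cc(Cl)c1` — 8400 nM

All three numbers come from an assay for binding affinity to Apoptosis regulator Bcl-2 (Homo sapiens), read by fluorescence polarization, with stated times of 30 min and 20 min; a higher number here means a weaker inhibitor, a lower number a stronger inhibitor. Compound 2 gives the highest number of the three; against compound 3 the gap is within the usual scatter, so the two are not separated, while against compound 1 the gap lies beyond the scatter, and compound 1 is the stronger binder of that pair. No pair of these compounds differs in only one place, so no single step can be read off directly.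

The next compound is compound 4 `Cc1ccc(-c2ccsc2S(=O)(=O)NCCNC(=O)Nc2cc(Cl)cc(Cl)c2)c(Oc2ccc(O)c(O)c2)c1`. It is compound 2 with the change (3,5-dichlorophenyl in place of 4-nitrophenyl on an amide-type nitrogen), that is, 3,5-dichlorophenyl in place of 4-nitrophenyl on an amide-type nitrogen. Compound 3 carries the same 3,5-dichlorophenyl on a urea and differs from compound 2 only within the scatter, so no step beyond the scatter is expected in this assay for this change; if anything a slightly lower number. Compound 4 is therefore expected at 8500 nM (range 3000 nM to 22000 nM), which amounts to an expected step of a 1.5-fold lower number from compound 2 to compound 4 (0.18 log units; within the scatter).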

Compound 4, inhibition constant: 2900 nM
Compound 4: the middle estimate sits 2.9-fold (0.47 log units) above what was measured; measured number outside the range, below it.
By their numbers in this assay, from the lowest: compounds 4, 1, 3 and 2 (each within the scatter of the next, the first and the last beyond it).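

In this assay, within the data shown here, the first single-place step can now be read: 3,5-dichlorophenyl in place of 4-nitrophenyl on an amide-type nitrogen gives a 4.5-fold lower number from compound 2 to compound 4 (0.65 log units; beyond the scatter). Among these compounds, this position is therefore not indifferent to the aryl group, since changing that group alone moves the number beyond the scatter, which the earlier compounds could not show because they differ from one another in more than one place. No measurement at hand accounts for the step.

From the compounds shown here alone, this is a single pair on a single core, so it remains open whether the same change gives a similar step on another core. Also open, going by these compounds, is how a carboxylic acid or an amine on this aryl ring, or a longer chain joining the sulfonamide and the urea, would read in this assay.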